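The source may hold more compounds than are shown below. What is called first, only, known or untested is meant among the compounds shown, and "the series" means these compounds.

In an ADME assay on HT-29 cells (Homo sapiens) for cytotoxicity, read by MTT assay, with a stated time of 72 h (on this read-out higher numbers stand for weaker inhibition and lower numbers for stronger inhibition), three compounds of one family have been measured so far. Compound 1, with the structure `COc1ccc(C2=C(c3cc(OC)c(OC)c(OC)c3)CC(O)C2=O)cc1[N+](=O)[O-]`, gives only a limit of the assay, > 100 ug/mL. Compound 2, with the structure `C=CCOc1cc(C2=C(c3cc(OC)c(OC)c(OC)c3)C(=O)C(O)C2)ccc1OC`, likewise gives only a limit, > 100 ug/mL. Among the compounds with values here, compound 3, with the structure `COc1ccc(C2=C(c3cc(OC)c(OC)c(OC)c3)C(=O)CC2O)cc1`, is the one compound with a number, and in this assay compound 3 gives 15 ug/mL. Compound 3 therefore stands alone on the numbers shown, the other two results being (the limit of > 100 ug/mL in this assay, at which 2 of the 3 values shown sit). No pair among these three differs in a single place, so no step between measured compounds can be read off, and the change from compound 3 to compound 4 has no measured counterpart here.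

Compound 4, with the structure `CCOC(=O)COc1ccc(C2=C(c3cc(OC)c(OC)c(OC)c3)C(=O)CC2O)cc1`, has not yet been measured in this assay. It differs from compound 3 by ethoxycarbonyl in place of hydrogen on a saturated chain carbon bound to an oxygen on an aromatic ring. The two compounds at the limit differ from compound 3 in other places, so they say nothing direct about this change. A step toward weaker inhibition is expected for compound 4, of the size a 2.7-fold higher number from compound 3 to compound 4 (0.43 log units; beyond the scatter). The estimate for compound 4 in this assay is 40 ug/mL, with a range from 12 ug/mL to 100 ug/mL, and a fair chance that only a limit is reported.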

Compound 4, half-maximal inhibitory concentration: > 100 ug/mL
Compound 4: no number, only a limit (the forecaster's own chance of this, stated with the estimate: 30%); middle value at least 2.5-fold (0.39 log units) away from the limit.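

In this assay, within the data shown here, ethoxycarbonyl in place of hydrogen on a saturated chain carbon bound to an oxygen on an aromatic ring gives an at least 6.6-fold higher number from compound 3 to compound 4 (0.82 log units; beyond the scatter), the first step in this family that can be read at all. From the compounds shown here alone, this shows that the position does not take the change from methoxy to (ethoxycarbonyl)methoxy without a clear move toward weaker inhibition, although the full size of that move stays unknown, since compound 4 gives only a limit of the assay and not a number. Among these compounds, compound 3 now remains the only compound with a number, and the rest of the family shares one ceiling: the limit of > 100 ug/mL in this assay, at which 3 of the 4 values shown sit.

One change cannot tell which part of the added group matters, and a plain ethoxy group, a carboxylic acid or an amide on the same chain would each test a different part of it. Steps involving compound 1 or compound 2 cannot be read, as both differ from compound 3 and compound 4 in other places.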